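Aryl urea piperidinylbutyl series: pyridyl to methoxyphenyl swap

The source may hold more compounds than are shown below. What is called first, only, known or untested is meant among the compounds shown, and "the series" means these compounds.

Measured so far:
compound 1, `O=C(NCCCCN1CCCCC1)Nc1ccc(-c2ccc(F)nc2)cc1`, > 30000 nM
compound 2, `O=C(NCCCCN1CCCCC1)Nc1ccc(-c2ccccc2)nc1`, > 30000 nM

Compound 1, `O=C(NCCCCN1CCCCC1)Nc1ccc(-c2ccc(F)nc2)cc1`, is measured in a functional assay on HEK293 cells for agonist activity at 5-hydroxytryptamine receptor 3A (Homo sapiens), read by FLIPR; a higher number here means a weaker inhibitor, a lower number a stronger inhibitor. The value for compound 1 in this assay, > 30000 nM, is a limit of the assay and not a number. Compound 2, `O=C(NCCCCN1CCCCC1)Nc1ccc(-c2ccccc2)nc1`, also returns a limit in this assay, > 30000 nM. Compound 1 therefore stands at the limit of > 30000 nM in this assay, at which 2 of the 2 values shown sit, and nothing in the two values shown separates the two compounds from each other.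

Compound 3, `COc1ccccc1-c1ccc(NC(=O)NCCCCN2CCCCC2)cc1`, is not yet measured in this assay. It differs from compound 1 in one place: 2-methoxyphenyl in place of 6-fluoropyridin-3-yl on an aromatic carbon. No step between measured compounds is available to calibrate this change, and both measured compounds sit at the limit, so no direction has been shown for any change on this core.

For the step from compound 1 to compound 3 in this assay, no change beyond the usual scatter is expected, and the estimated step is a number no higher from compound 1 to compound 3 (the limit leaves the size open). For compound 3 the expected value in this assay is 30000 nM, within an expected range from 8000 nM to 100000 nM, with a substantial chance that the assay again reports only a limit.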

Compound 3, half-maximal inhibitory concentration: 7800 nM
Estimate against measurement, compound 3: 3.8-fold (0.59 log units) above; measured number below the stated range.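

In this assay compound 1 gives > 30000 nM, a limit of the assay and not a number. Among the compounds shown here, with 2-methoxyphenyl in place of 6-fluoropyridin-3-yl, on an aromatic carbon para to a large group, the series shows an at least 3.8-fold lower number from compound 1 to compound 3 (0.58 log units; beyond the scatter), the first sign that the group at this position can move the read-out on the shared core, though the full size of the change stays open. Compound 3 is the only compound shown that returns a number, and the rest of the set still gives no direction of its own: the limit of > 30000 nM in this assay, at which 2 of the 3 values shown sit.

The swap replaces the ring and its substituent together, so the compounds shown do not separate the contribution of the methoxy group from that of the carbon-only ring in place of the fluoropyridine. Also open, as far as these compounds go, is how a plain phenyl or a 2-ethoxyphenyl at this position would compare with compound 3, and whether the change carries over to cores with a longer chain or an amine other than piperidine.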